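The source may hold more compounds than are shown below. What is called first, only, known or untested is meant among the compounds shown, and "the series" means these compounds.

Measured so far in a functional assay on aorta (Rattus norvegicus, strain Wistar); on this read-out higher numbers stand for weaker inhibition and lower numbers for stronger inhibition:
- Compound 1 `Cc1ccc2c(c1)N(C1=CCCC1=O)CC(C)(C)S2` gives 933 nM
- Compound 2 `CCc1ccc2c(c1)N(C1=CCCC1=O)CC(C)(C)S2` gives 155 nM
- Compound 3 `CC1(C)CN(C2=CCCC2=O)c2cc(C(F)(F)F)ccc2S1` gives 0.0417 nM

Compound 3 has the lowest number of the three, and so is the strongest inhibitor here. Compound 4 `CC1(C)CN(C2=CCCC2=O)c2ccccc2S1` has hydrogen in place of trifluoromethyl on an aromatic carbon. Going by the values given here, no measured compound carries hydrogen there, so the nearest evidence comes from its neighbours. Putting trifluoromethyl in place of methyl gave a large drop (a 22000-fold lower number from compound 1 to compound 3 (4.35 log units; beyond the scatter)), and putting it in place of ethyl gave another (a 3700-fold lower number from compound 2 to compound 3 (3.57 log units; beyond the scatter)). Methyl to ethyl moved the number far less (a 6.0-fold lower number from compound 1 to compound 2 (0.78 log units; beyond the scatter)). Removing trifluoromethyl should therefore give a large rise, and the estimated step is similar in size (a 24000-fold higher number from compound 3 to compound 4 (4.38 log units; beyond the scatter)). Compound 4 is expected near 1000 nM, with an estimated range from 100 nM to 10000 nM.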

Compound 4, half-maximal inhibitory concentration: 724 nM
Compound 4: middle estimate off by 1.4-fold (0.14 log units), on the high side, and the stated range covers the measured number.
By their numbers in this assay, from the lowest: compound 3; then compound 2; then compounds 4 and 1 (each within the scatter of the next).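

Measured against hydrogen, the large effect at this position belongs to trifluoromethyl alone: replacing it with hydrogen gives a very large step (a 17000-fold higher number from compound 3 to compound 4 (4.24 log units; beyond the scatter)), whereas replacing ethyl gives a much smaller one (a 4.7-fold higher number from compound 2 to compound 4 (0.67 log units; beyond the scatter)) and replacing methyl gives one that stays within the scatter (a 1.3-fold lower number from compound 1 to compound 4 (0.11 log units; within the scatter)). Simply having a group on this aromatic carbon is therefore not enough to give a number as low as that of compound 3. Nothing available explains why trifluoromethyl stands so far apart from methyl and ethyl.

Still open, going by these compounds, is whether a chlorine atom, a nitrile or a methoxy group here would behave like trifluoromethyl or like methyl and ethyl. Also open, on these data alone, is how a longer chain, such as propyl, would compare with ethyl.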